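A few compounds are considered here, and "the series" means these few. Any claim that something is new, unique, unknown or untested is made for them only; others in the source may bear on it.

Three compounds share one core and differ only in the amine on the thiocarbonyl carbon. Compound 1 `O=C(CC(SC(=S)N1CCCC1)c1ccccc1)c1ccccc1` gives 1670 nM in a functional assay on the whole organism for inhibition, with Cicer arietinum as the target, with a stated time of 7 days; on this read-out higher numbers stand for weaker inhibition and lower numbers for stronger inhibition. Compound 2 `O=C(CC(SC(=S)N1CCCCC1)c1ccccc1)c1ccccc1` gives 1850 nM in this assay, and compound 3 `CN(C)C(=S)SC(CC(=O)c1ccccc1)c1ccccc1` gives 2430 nM in this assay. Compound 3 has the highest of the three numbers, but its gaps to the other two are small: a 1.3-fold higher number from compound 2 to compound 3 (0.12 log units; within the scatter) and a 1.5-fold higher number from compound 1 to compound 3 (0.16 log units; within the scatter). The remaining step, a 1.1-fold higher number from compound 1 to compound 2 (0.04 log units; within the scatter), is likewise small. Compound 4 `CCN(CC)C(=S)SC(CC(=O)c1ccccc1)c1ccccc1` has not yet been measured; it differs from compound 3 in that (diethylamino in place of dimethylamino on a thiocarbonyl carbon). All three measured steps exchange the amine on this same thiocarbonyl carbon, and none of them moved this assay beyond the scatter, so the exchange leading to compound 4 is expected to behave in the same way, with no step beyond the scatter in either direction. Compound 4 is therefore expected to give 2400 nM in this assay, within a range from 1200 nM to 4800 nM. The step that this estimate means, a 1.0-fold lower number from compound 3 to compound 4 (0.01 log units; within the scatter), is expected to stay within the scatter.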

Compound 4, half-maximal inhibitory concentration: 1840 nM
Compound 4: the middle estimate sits 1.3-fold (0.12 log units) above what was measured; the measured number falls inside the stated range.
By their numbers in this assay, from the lowest: compounds 1, 4, 2 and 3 (each within the scatter of the next).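

In this assay the step from the dimethylamino group to the larger open-chain diethylamino group on the thiocarbonyl carbon, with 5 heavy atoms in place of 3, gives a 1.3-fold lower number from compound 3 to compound 4 (0.12 log units; within the scatter) and so adds a fourth amine to the set without leaving the scatter. The comparison with the ring amines reads the same: diethylamino in place of piperidin-1-yl gives a 1.0-fold lower number from compound 2 to compound 4 (0.00 log units; within the scatter) and in place of pyrrolidin-1-yl gives a 1.1-fold higher number from compound 1 to compound 4 (0.04 log units; within the scatter) for the same read-out. Compound 4 therefore shows that, among these four compounds, neither lengthening the open-chain groups from methyl to ethyl nor opening the ring separates the values in this assay. Nothing given here explains why these amines read alike.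

The compounds shown leave open whether this flat picture holds for amines of another kind on the same carbon, such as a morpholin-4-yl or piperazin-1-yl ring, or for a longer chain such as dibutylamino. They also leave open whether a change elsewhere on the shared core would move the values beyond the scatter, since all four differ only in this amine.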